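Cyclohexyl to ethyl on an amide-type nitrogen: series notes

The source may report more compounds than this note shows. Statements on the series, on what has been measured and on what is new or still open speak of the compounds shown alone.

Measured compounds in a functional assay on the whole organism (blood, strain albino) with Mus musculus as the target, with stated times of 6 days and 4 h, at a dose of 0.4 mmol/kg by the oral route; a higher number here means more inhibition at the dose given (going by the name of the read-out), a lower number less inhibition:

compound 1 `CCNC(=O)NS(=O)(=O)c1ccc(-n2nc(C(=O)O)cc2C)cc1`: 0%
compound 2 `Cc1cc(C(=O)O)nn1-c1ccc(S(=O)(=O)NC(=O)NC2CCCCC2)cc1`: 1%
compound 3 `Cc1cc(C)n(-c2ccc(S(=O)(=O)NC(=S)NC3CCCCC3)cc2)n1`: < 2%, a limit of the assay, not a number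

Compound 1 and compound 2 share a core and differ in one place, (ethyl in place of cyclohexyl on an amide-type nitrogen). The step of a number 1 percentage points lower from compound 2 to compound 1 (within the scatter), so in this assay the two values are indistinguishable. Going by the values given here, for compound 3 the read-out is known only as a limit; it is the one of the three values sitting at the limit of < 2% in this assay, at which 1 of the 3 values shown sits. How the core of compound 3 differs from that of compound 2 is not broken down here.

Compound 4 `CCNC(=S)NS(=O)(=O)c1ccc(-n2nc(C)cc2C)cc1` is not yet measured. It differs from compound 3 by ethyl in place of cyclohexyl on an amide-type nitrogen. This is the same kind of change as from compound 2 to compound 1, not the same: in compound 4 the nitrogen's other neighbour is a thiocarbonyl carbon, in compound 1 a carbonyl carbon.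

The expected step that the limit leaves unreadable from compound 3 to compound 4 rests on the measured pair, where the step of a number 1 percentage points lower from compound 2 to compound 1 (within the scatter) and so left the read-out flat. Since compound 3 stands at a limit, a limit is likely again for compound 4. The estimate for compound 4 in this assay is 1%, with a range from 0% to 6%.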

Compound 4, a percentage reported as inhibition, in the whole organism at one dose (the size of the read-out at that dose, not a potency): 0%
Compound 4: the middle estimate sits 1 percentage points above what was measured; the measured number falls inside the stated range.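

No step can be read from compound 3 to compound 4 in this assay. The value of compound 3 is a limit of the assay and not a number: the limit of < 2% in this assay, at which 1 of the 4 values shown sits.

The compounds shown leave open whether ethyl in place of cyclohexyl changes the read-out at all on an amide-type nitrogen whose other neighbour is a thiocarbonyl carbon.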